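This account rests on a few compounds, and the source may have more. Where it says the series, first, only, none or still open, it means among the compounds named here.

Compound 1 `C=C1C(=O)O[C@H]2CC3=C[C@H](C/C(C)=C/[C@@H](OC(=O)/C=C/c4ccccc4)[C@H]12)OC3=O` carries the (2-phenylethenyl)carbonyl ester on the shared core and, in a functional assay on A549 cells (Homo sapiens) for cytotoxicity, read by MTT assay, with a stated time of 48 h (a lower number here means a stronger inhibitor, a higher number a weaker inhibitor), compound 1 gives 4800 nM, the lowest of the two numbers in hand. Compound 3 `C=C1C(=O)O[C@H]2CC3=C[C@H](C/C(C)=C/[C@@H](OC(=O)CC4CCCCC4)[C@H]12)OC3=O` gives 6900 nM in this assay. Compound 2 `C=C1C(=O)O[C@H]2CC3=C[C@H](C/C(C)=C/[C@@H](OC(=O)CCl)[C@H]12)OC3=O` reaches > 10000 nM, which is a limit of this assay and not a number. Compound 4 `C=C1C(=O)O[C@H]2CC3=C[C@H](C/C(C)=C/[C@@H](OC(=O)C4CC4)[C@H]12)OC3=O` differs from compound 1 by cyclopropyl in place of 2-phenylethenyl on a carbonyl carbon. Going by the values given here, the steps that bear on this change are a 1.4-fold higher number from compound 1 to compound 3 (0.16 log units; within the scatter) and an at least 2.0-fold higher number from compound 1 to compound 2 (0.31 log units; beyond the scatter); both remove the 2-phenylethenyl group, and neither lowers the number. Compound 4 is therefore expected to show a 1.8-fold higher number from compound 1 to compound 4 (0.25 log units; within the scatter), a weakening, with a real chance that only a limit is reported, as with the limit of > 10000 nM in this assay, at which 1 of the 3 values shown sits. The estimate for compound 4 is 8500 nM, between 3500 nM and 20000 nM.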

Compound 4, half-maximal inhibitory concentration: 3200 nM
Compound 4: middle estimate off by 2.7-fold (0.42 log units), on the high side; the whole stated range lies above it.
By their numbers in this assay, from the lowest: compounds 4, 1 and 3 (each within the scatter of the next, the first and the last beyond it). At a limit, above all of these: compound 2.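

In this assay, the six-membered aromatic ring and the double bond of 2-phenylethenyl prove dispensable on this carbonyl carbon, with a 1.5-fold lower number from compound 1 to compound 4 (0.18 log units; within the scatter). Cyclopropyl also separates from the other two groups at this place, with a 2.2-fold lower number from compound 3 to compound 4 (0.33 log units; beyond the scatter) and an at least 3.1-fold lower number from compound 2 to compound 4 (0.49 log units; beyond the scatter). Compound 2 stands at a limit and not a number: the limit of > 10000 nM in this assay, at which 1 of the 4 values shown sits.

As far as these compounds go, whether a longer unbranched chain, an amine or a carboxylic acid on this carbonyl carbon would keep the number remains open. Also open, from the compounds shown here alone, is whether cyclobutyl would track with cyclopropyl or with cyclohexylmethyl.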